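Swapping a phenyl for a pyridinyl on two triazole cores

The compounds below may be only part of what the source reports. "The series", "measured", "known", "first", "only" and "open" are said of these compounds alone.

Compound 1 `OC1(c2nnc(-c3ccccc3)[nH]2)CCCCC1` and compound 2 `OC1(c2nnc(-c3ccncc3)[nH]2)CCCCC1` share a core; compound 3 `OC1CCC(C(O)c2nnc(-c3ccccc3)[nH]2)CC1O` and compound 4 `OC1CCC(C(O)c2nnc(-c3ccncc3)[nH]2)CC1O` share another. How the two cores differ is not broken down here. In an ADME assay on Vero cells (Chlorocebus sabaeus) for cytotoxicity, read by MTT assay, with a stated time of 72 h (a lower number here means that less compound is tolerated, a higher number that more compound is tolerated), compound 1 gives 422 ug/mL, compound 2 gives 412 ug/mL, and compound 3 gives 429 ug/mL. The change pyridin-4-yl in place of phenyl on an aromatic carbon made the step of a 1.0-fold lower number from compound 1 to compound 2 (0.01 log units; within the scatter). The change pyridin-4-yl in place of phenyl on an aromatic carbon is the same kind of change, though here the ring atom that bears a large group, rather than a group of 7 heavy atoms, sits two ring bonds away. Because a 1.0-fold lower number from compound 1 to compound 2 (0.01 log units; within the scatter) lay within the scatter, the step from compound 3 to compound 4 in this assay is expected to be similar, a 1.0-fold lower number from compound 3 to compound 4 (0.01 log units; within the scatter). Compound 4 is therefore estimated at 420 ug/mL, with a likely range from 300 ug/mL to 560 ug/mL.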

Compound 4, half-maximal cytotoxic concentration: 429 ug/mL
Compound 4: middle estimate off by 1.0-fold (0.01 log units), on the low side; measured number inside the range.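

In this assay, putting pyridin-4-yl in place of phenyl on the second core gave no change at the digits printed from compound 3 to compound 4 (within the scatter), which matches what the same swap did on the first core. The two steps can be set side by side: the same change on two cores in this assay, a 1.0-fold lower number (0.01 log units; within the scatter) from compound 1 to compound 2 and no change at the digits printed (within the scatter) from compound 3 to compound 4, 1.0-fold (0.01 log units) apart, within the scatter of two such steps. So on these two cores the swap carries over without a change beyond the scatter, but two pairs in one assay do not show why, or that the same would hold on a third core.

The compounds shown have only phenyl or pyridin-4-yl at this place on the triazole. As far as these compounds go, what an amine or a carboxylic acid there would do to the tolerated concentration remains open.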